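Tertiary alcohol in place of propanoyl

The source may report more compounds than this note shows. Statements on the series, on what has been measured and on what is new or still open speak of the compounds shown alone.

Compound 3 `CCC(=O)c1ccccc1CC[C@H](SC[C@@H](C)C(=O)O)c1cccc(/C=C/c2ccc3ccc(Cl)cc3n2)c1` gives 3.7 nM in an assay on membranes from lung for inhibition of cysteinyl leukotriene receptor 1 (Cavia porcellus); a higher number here means a weaker inhibitor, a lower number a stronger inhibitor. Compound 2 `CCOC(=O)c1ccccc1CC[C@H](SC[C@@H](C)C(=O)O)c1cccc(/C=C/c2ccc3ccc(Cl)cc3n2)c1` gives 3.7 nM, and no change at the digits printed from compound 2 to compound 3 (within the scatter); together they are the two highest of the three numbers. Compound 1 `C[C@H](CS[C@@H](CCc1cccc(CO)c1)c1cccc(/C=C/c2ccc3ccc(Cl)cc3n2)c1)C(=O)O` gives 2.1 nM, and a 1.8-fold higher number from compound 1 to compound 3 (0.25 log units; within the scatter), while a 1.8-fold higher number from compound 1 to compound 2 (0.25 log units; within the scatter). Compound 4 `C[C@H](CS[C@@H](CCc1ccccc1CC(C)(C)O)c1cccc(/C=C/c2ccc3ccc(Cl)cc3n2)c1)C(=O)O` carries 2-hydroxy-2-methylpropyl in place of propanoyl on an aromatic carbon, on an aromatic carbon of a six-membered aromatic ring of carbon only, ortho to a large group. The measured steps in this assay, the two swaps on the saturated chain carbon and the exchange on the carbonyl carbon, all stayed within the scatter. Compound 4 is therefore expected to show no step beyond the scatter, a 1.1-fold lower number from compound 3 to compound 4 (0.02 log units; within the scatter). The estimate for compound 4 is 3.5 nM, ranging from 1.2 nM to 10 nM.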

Compound 4, half-maximal inhibitory concentration: 1 nM
Compound 4: the middle estimate sits 3.5-fold (0.54 log units) above what was measured; the measured number lies below the stated range.
By their numbers in this assay, from the lowest: compound 4; then compounds 1, 2 and 3 (each within the scatter of the next).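

In this assay, replacing the groups on this aromatic carbon now gives a step beyond the scatter: 2-hydroxy-2-methylpropyl in place of propanoyl gives (a 3.7-fold lower number from compound 3 to compound 4 (0.57 log units; beyond the scatter)), and in place of ethoxycarbonyl it gives (a 3.7-fold lower number from compound 2 to compound 4 (0.57 log units; beyond the scatter)), whereas the exchange between those two earlier groups had stayed within the scatter. The change of the whole aryl group from 3-(hydroxymethyl)phenyl to 2-(2-hydroxy-2-methylpropyl)phenyl also gives a modest step (a 2.1-fold lower number from compound 1 to compound 4 (0.32 log units; beyond the scatter)), so compound 4 alone stands clear of the other three. Nothing measured here accounts for these steps.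

The compounds shown leave open how a secondary alcohol, an amine or a carboxylic acid would read on this aromatic carbon. They also leave open whether the tertiary alcohol would hold its step on a longer chain.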